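A few compounds are considered here, and "the series" means these few. Any claim that something is new, unique, unknown or untested is made for them only; others in the source may bear on it.

For the measured compounds named here, compound 2, `N#Cc1cn([C@H]2C[C@H](O)[C@@H](CO)O2)c(=O)[nH]c1=O`, is one of three compounds measured in an ADME assay on L1210/0 cells (Mus musculus) for cytotoxicity, with a stated time of 48 h (on this read-out lower numbers stand for stronger inhibition and higher numbers for weaker inhibition), where compound 2 gives > 200000 nM, a limit of the assay rather than a number. Compound 1, `CC(=O)OCCOCn1cnc2c(Cl)nc(I)nc21`, gives 8600 nM in this assay. Compound 3, `CC(=O)OCCOCn1cnc2c(Cl)nc(N)nc21`, gives > 200000 nM, also a limit. Going by the values given here, the one measured step, an at least 23-fold higher number from compound 1 to compound 3 (1.36 log units; beyond the scatter), is summarised by the limit of > 200000 nM in this assay, at which 2 of the 3 values shown sit. Compound 4, `CCCC/C=C\c1cn([C@H]2C[C@H](O)[C@@H](CO)O2)c(=O)[nH]c1=O`, differs from compound 2 by hex-1-en-1-yl in place of cyano on an aromatic carbon. Among the compounds with values here, no measured step involves this change, and compound 2 itself sits at a limit, so no direction can be read from the data. The account expects compound 4 to give about 150000 nM in this assay, with a range from 30000 nM to 400000 nM, which means an expected step of an at least 1.3-fold lower number from compound 2 to compound 4 (0.12 log units; that floor lies within the scatter).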

Compound 4, half-maximal inhibitory concentration: > 200000 nM
Compound 4 was reported as a limit; the forecaster's own chance of this, stated with the estimate: 60%; at least 1.3-fold (0.12 log units) between middle value and limit.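

In this assay, for the compounds shown here, compound 2 and compound 4 both stand at a limit, and no step between them can be read. The compounds shown leave open whether hex-1-en-1-yl in place of cyano changes the read-out at all.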